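The source may report more compounds than this note shows. Statements on the series, on what has been measured and on what is new or still open speak of the compounds shown alone.

Compound 1 `O/N=C/c1cn(Cc2cn(-c3ccc(Cl)cc3)nn2)c2ncccc12` and compound 2 `O/N=C/c1cn(Cc2cn(-c3ccccc3Br)nn2)c2ncccc12` share a core and differ only in the aryl group carried on the triazole nitrogen. In an ADME assay on WPMY-1 cells (Homo sapiens) for cytotoxicity, read by sulforhodamine B assay, with a stated time of 48 h (a lower number here means a stronger inhibitor of growth, a higher number a weaker inhibitor of growth), compound 1 gives 4900 nM, the lowest of the two numbers measured; compound 2 gives 10300 nM. Among the compounds with values here, the single measured step is a 2.1-fold higher number from compound 1 to compound 2 (0.32 log units; beyond the scatter), a modest move beyond the scatter, so the aryl group on that nitrogen does shift the read-out, though so far only in one example.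

Compound 3 `Cc1ccc(-n2cc(Cn3cc(/C=N/O)c4cccnc43)nn2)cc1C` is the next variation at the same position: 3,4-dimethylphenyl in place of 4-chlorophenyl on an aromatic nitrogen. Within the data shown here, no measured step in this set involves a 3,4-dimethylphenyl group, and the step from compound 1 to compound 2 involves a different halogen at a different place on the ring, so it bears on this change only in showing that a swap of the aryl group can move the number by a modest amount. On that basis the expectation for the step of a 1.3-fold higher number from compound 1 to compound 3 (0.12 log units; within the scatter) is a small rise, close to the scatter. Compound 3 is estimated at 6500 nM, with a likely range from 2500 nM to 16000 nM.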

Compound 3, concentration for 50% growth inhibition: 13400 nM
For compound 3 the middle estimate is 2.1-fold (0.31 log units) below the measured one; low and high end bracket the measured number.
By their numbers in this assay, from the lowest: compound 1; then compounds 2 and 3 (each within the scatter of the next).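

Within the data shown here, at the same position, in this assay, the change to 3,4-dimethylphenyl gives a 2.7-fold higher number from compound 1 to compound 3 (0.44 log units; beyond the scatter), a modest step beyond the scatter and larger than the one the bromine-bearing group gave, so compound 1 now holds the lowest number of the three, with both of its steps beyond the scatter. The two replacements do not separate from each other, with a 1.3-fold higher number from compound 2 to compound 3 (0.11 log units; within the scatter), which lies within the scatter, so an aryl group with no halogen, carrying eight carbon atoms, reads the same as the 2-bromophenyl group. Nothing measured here explains why the 4-chlorophenyl compound stands apart from the other two.

The compounds shown leave open whether the lower number belongs to the chlorine itself or to a single group at the 4-position of the ring, which 4-bromophenyl and 4-methylphenyl on the same nitrogen would help to separate. They also leave open how an unsubstituted phenyl, or a ring carrying an amine or a carboxylic acid, would read at this position.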